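Trifluoromethyl Ketone in Place of Pyridyl: An Expected Step

A few compounds are considered here, and "the series" means these few. Any claim that something is new, unique, unknown or untested is made for them only; others in the source may bear on it.

Of the compounds shown here, three have been measured in an assay for inhibition of Fatty-acid amide hydrolase 1 (Rattus norvegicus); on this read-out lower numbers stand for stronger inhibition and higher numbers for weaker inhibition. Compound 1 `NC(=O)c1ccc(-c2cnc(C(O)CCc3ccc(-c4ccccc4)cc3)o2)nc1` reaches only the limit of the assay, giving > 1000 nM in this assay, which is a limit rather than a number. Compound 2 `O=C(CCc1ccc(-c2ccccc2)cc1)c1ncc(-c2ccncc2)o1` gives 2.3 nM in this assay. Compound 3 `O=C(O)c1cccc(-c2cnc(C(=O)CCc3ccc(-c4ccc(CN5CCCCC5)cc4)cc3)o2)n1` gives 44 nM in this assay. Of the two numbers that are not limits, compound 2 holds the lower one, and the gap to compound 3 lies beyond the usual scatter, so compound 2 is the stronger inhibitor of that pair. Compound 4 `O=C(CCc1ccc(-c2ccccc2)cc1)c1ncc(C(=O)C(F)(F)F)o1` is not yet measured. It differs from compound 2 in one place: (trifluoromethyl)carbonyl in place of pyridin-4-yl on an aromatic carbon. Within the data shown here, no measured pair of compounds traces this kind of change, so the size of the step rests on judgement alone. For compound 4 the estimate in this assay is 20 nM, with a plausible range from 3 nM to 150 nM. That estimate means a step of an 8.7-fold higher number from compound 2 to compound 4 (0.94 log units; beyond the scatter), expected to run toward weaker inhibition, though with little confidence about how far.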

Compound 4, inhibition constant: 8 nM
Estimate against measurement, compound 4: 2.5-fold (0.40 log units) above; measured number inside the range.
By their numbers in this assay, from the lowest: compound 2; then compound 4; then compound 3. At a limit, above all of these: compound 1.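

Among these compounds, replacing pyridin-4-yl with (trifluoromethyl)carbonyl gives the first direct reading at this position, the aromatic carbon next to the ring oxygen: in this assay the change costs a modest amount of strength (a 3.5-fold higher number from compound 2 to compound 4 (0.54 log units; beyond the scatter)). A ring is therefore not needed here for nanomolar inhibition, since compound 4 carries a group with no ring at all. The two groups do share one hydrogen-bond acceptor and the same heavy-atom count, yet the pyridin-4-yl of compound 2 still gives the lower number.

No evidence available here explains why the number moves with this change. On these data alone, whether a nitrile, a simple amine or a longer carbon chain at this same position would stay close to compound 2 or fall further away remains open.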